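The source may report more compounds than this note shows. Statements on the series, on what has been measured and on what is new or still open speak of the compounds shown alone.

Measured compounds:
Compound 1, `CCOc1ccc(-c2cccc([N+](=O)[O-])c2)cc1`, gives 35% in an assay on COS-7 cells for inhibition of patatin-like phospholipase domain-containing protein 2 (Mus musculus), tested at 200 uM; a higher number here means more inhibition at the concentration tested (going by the name of the read-out), a lower number less inhibition.
Compound 2, `CN(C)c1ccc(-c2cccc([N+](=O)[O-])c2)cc1`, gives 21% in this assay.

Among the compounds with values here, compound 2 stands lowest of the two numbers measured so far; its nearest neighbour is compound 1, and the step of a number 14 percentage points lower from compound 1 to compound 2 (beyond the scatter) lies beyond the scatter. Compound 3, `CCOC(=O)Nc1cccc(-c2ccc(N(C)C)cc2)c1`, has not yet been measured. It differs from compound 2 in one place: (ethoxycarbonyl)amino in place of nitro on an aromatic carbon. Within the data shown here, the only measured step, a number 14 percentage points lower from compound 1 to compound 2 (beyond the scatter), changes a group on the other ring and says nothing about exchanging the nitro group, so no measured step bears directly on this change. With nothing to guide the direction, the expectation is a step of no clear size beyond the scatter, a number 4 percentage points higher from compound 2 to compound 3 (within the scatter), with a wide range either way. Compound 3 is therefore estimated at 25%, between 5% and 50%.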

Compound 3, a percentage reported as inhibition, at one concentration (the size of the read-out at that concentration, not a potency): 93%
Estimate against measurement, compound 3: 68 percentage points below; measured number outside the range, above it.
By their numbers in this assay, from the lowest: compound 2; then compound 1; then compound 3.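

Within the data shown here, exchanging the nitro group for (ethoxycarbonyl)amino on this aromatic carbon gives a large step in this assay, a number 72 percentage points higher from compound 2 to compound 3 (beyond the scatter), so this position, which the earlier compounds did not vary, can strongly change the read-out. The earlier step, a number 14 percentage points lower from compound 1 to compound 2 (beyond the scatter), was only modest by comparison. The entering group has 6 heavy atoms where nitro has 3, and it adds 1 hydrogen-bond donor, but nothing measured here explains the size of the step.

Going by these compounds, it remains open which part of the (ethoxycarbonyl)amino group matters, since a plain amine or an acetamide at this position would separate the nitrogen with its hydrogen from the rest of the chain. Also open, on these data alone, is whether the same exchange has a similar effect when ethoxy replaces dimethylamino, as in compound 1.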